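The compounds below may be only part of what the source reports. "The series", "measured", "known", "first", "only" and "open" are said of these compounds alone.

Compound 3 `Cc1ccc(-c2nc(N)c3cc(Cc4ccccc4Cl)sc3n2)o1` gives 26.1 nM in a functional assay on CHO-K1 cells for antagonist activity at adenosine receptor A1 (Homo sapiens), read by a beta-galactosidase reporter and cAMP accumulation, with stated times of 15 min and 6 h (a higher number here means a weaker inhibitor, a lower number a stronger inhibitor), the lowest of the three numbers obtained so far. Compound 1 `Cc1ccc(-c2nc(N)c3ccsc3n2)o1` gives 493 nM in this assay, and compound 2 `Cc1ccc(-c2nc(N)c3cc(CCc4ccccc4)sc3n2)o1` gives 2780 nM. All three measured steps concern the substituent on the aromatic carbon of the shared core: a 5.6-fold higher number from compound 1 to compound 2 (0.75 log units; beyond the scatter), a 19-fold lower number from compound 1 to compound 3 (1.28 log units; beyond the scatter), and a 110-fold lower number from compound 2 to compound 3 (2.03 log units; beyond the scatter). Compound 4 `N#Cc1cccc(-c2nc(N)c3cc(Cc4ccccc4Cl)sc3n2)c1` differs from compound 3 at a different place: 3-cyanophenyl in place of 5-methylfuran-2-yl on an aromatic carbon. Among the compounds with values here, none of the measured steps alters this group, so they bear on the change only in showing how widely the numbers can move; they do not tell the direction here. The group that enters carries one hydrogen-bond acceptor, as does the group that leaves. The step in this assay is therefore expected to be modest, a 2.3-fold higher number from compound 3 to compound 4 (0.36 log units; beyond the scatter), with wide uncertainty around it. In this assay compound 4 is expected to give 60 nM, between 10 nM and 400 nM.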

Compound 4, inhibition constant: 24.8 nM
Compound 4: middle estimate off by 2.4-fold (0.38 log units), on the high side; low and high end bracket the measured number.
By their numbers in this assay, from the lowest: compounds 4 and 3 (each within the scatter of the next); then compound 1; then compound 2.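

In this assay, 3-cyanophenyl in place of 5-methylfuran-2-yl gives a 1.1-fold lower number from compound 3 to compound 4 (0.02 log units; within the scatter) and so shows that this position, between two ring nitrogen atoms, can carry either a five-membered aromatic ring with 1 hetero atom or a six-membered aromatic ring of carbon only with no difference beyond the scatter. Within the data shown here, the earlier steps all concerned the substituent at the other place on the shared core, so this is the only reading of the present position, and it is taken with the 2-chlorobenzyl group in place. No measurement available here speaks to why the two groups read alike.

Among these compounds, whether the same holds with hydrogen or phenethyl at the other place remains open, since only this one pair bears on the exchange. Also open, on these data alone, is how an aromatic ring carrying an amine or a carboxylic acid would read at this position.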